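The compounds below may be only part of what the source reports. "The series", "measured", "known", "first", "only" and "open" are said of these compounds alone.

Of the compounds shown here, three sharing one core have been measured in a functional assay on MGC-803 cells (Homo sapiens) for inhibition, read by sulforhodamine B assay; a higher number here means a weaker inhibitor, a lower number a stronger inhibitor. Compound 1 `CCCc1ccc(NC2=CC(=O)c3nc4n(c3C2=O)[C@H]2OC[C@@H](O)[C@H]2OC4)cc1` gives 1560 nM, compound 3 `CCOc1ccc(NC2=CC(=O)c3nc4n(c3C2=O)[C@H]2OC[C@@H](O)[C@H]2OC4)cc1` gives 1110 nM, and compound 2 `O=C1C(Nc2ccc(Br)cc2)=CC(=O)c2c1nc1n2[C@H]2OC[C@@H](O)[C@H]2OC1` gives 2020 nM. Compound 2 has the highest number of the three, but its gap to compound 1 and to compound 3 is within the scatter, so no order among them can be claimed. Among the measured compounds shown here, the one step between measured neighbours, a 1.4-fold lower number from compound 1 to compound 3 (0.15 log units; within the scatter), changes only the group on the aromatic ring and also stays within the scatter.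

Compound 4 `O=C1C(NCc2ccccc2)=CC(=O)c2c1nc1n2[C@H]2OC[C@@H](O)[C@H]2OC1` is not yet measured. It differs from compound 2 by benzyl in place of 4-bromophenyl on an amine nitrogen. For the measured compounds named here, no measured step touches the amine nitrogen itself or swaps an aromatic ring for a benzyl group, so the measured data give no direct guide. The change is larger than the ring-substituent swap seen between compound 1 and compound 3, and a wide range is therefore expected. The estimate for compound 4 is 3500 nM, with a range from 1200 nM to 10000 nM, which means an expected step of a 1.7-fold higher number from compound 2 to compound 4 (0.24 log units; within the scatter).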

Compound 4, half-maximal inhibitory concentration: 3490 nM
For compound 4 the middle estimate is 1.0-fold (0.00 log units) above the measured one; measured number inside the range.
By their numbers in this assay, from the lowest: compounds 3, 1, 2 and 4 (each within the scatter of the next, the first and the last beyond it).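

In this assay the change at the amine nitrogen itself, a 1.7-fold higher number from compound 2 to compound 4 (0.24 log units; within the scatter), stays within the scatter, so the numbers do not separate benzyl from 4-bromophenyl at this position. The earlier step altered only a group on the aromatic ring, whereas this one replaces the whole group on the nitrogen, and the two numbers still cannot be told apart, even though the entering group has a carbon where the leaving group has a bromine. Nothing measured here explains this result.

The compounds shown leave open whether 4-bromobenzyl, which would keep the bromine on the benzyl group, or a longer chain such as phenylethyl on the same nitrogen would give a number beyond the scatter. They also leave open the effect of a carboxylic acid or an amine on the aromatic ring.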